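Replacing the terminal acid of compound 2 with a methyl sulfoxide

The source may hold more compounds than are shown below. What is called first, only, known or untested is meant among the compounds shown, and "the series" means these compounds.

Three analogues sharing one core have been measured in an assay on isolated protein for inhibition of leukotriene B4 receptor 1 (Homo sapiens), tested at 10 uM; on this read-out higher numbers stand for more inhibition at the one concentration tested (going by the name of the read-out) and lower numbers for less inhibition. Compound 1 `CC(=O)c1ccc(OCCCCC#N)cc1O` gives 0%. Compound 3 `C=CCc1cc(C(C)=O)c(O)cc1OCCCCC` gives 60%. Compound 2 `CCc1cc(C(C)=O)c(O)cc1OCCCCCC(C)(C)C(=O)O` gives 104%, the highest of the three numbers: its nearest neighbour is compound 3, whose number lies beyond the scatter below it, and compound 1 lies furthest below it, also beyond the scatter.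

The new compound 4 `CCc1cc(C(C)=O)c(O)cc1OCCCCCC[S+](C)[O-]` is derived from compound 2 by a single change: a group of 4 heavy atoms (2 carbon, 1 oxygen, 1 sulfur; no ring) in place of a group of 6 heavy atoms (4 carbon, 2 oxygen; no ring), on a saturated chain carbon, five bonds along the chain from an oxygen on an aromatic ring. Within the data shown here, no step between two measured compounds isolates this change, so the account can only lean on what the three measured values show. Compound 3, which carries a plain chain without any acid, gives 60%, and compound 1, with a nitrile at the end of its chain, gives 0%. Compound 4 is therefore expected to fall below compound 2, with a step of a number 49 percentage points lower from compound 2 to compound 4 (beyond the scatter) in this assay. The estimate for compound 4 is 55%, with a range from 20% to 90%.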

Compound 4, a percentage reported as inhibition, at one concentration (the size of the read-out at that concentration, not a potency): 92%
Compound 4: middle estimate off by 37 percentage points, on the low side, and the stated range ends below it.
By their numbers in this assay, from the lowest: compound 1; then compound 3; then compound 4; then compound 2.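

Exchanging the 1-carboxy-1-methylethyl group at the end of the chain for the methyl sulfoxide in this assay gives a number 12 percentage points lower from compound 2 to compound 4 (beyond the scatter), a modest step that lies beyond the scatter. This single-change pair shows that the carboxylic acid is not needed at this position for a high reading, and that the entering group, with 0 hydrogen-bond donors, retains most of the inhibition seen with the leaving group, which has 1. Nothing available accounts for why the loss is no larger.

The compounds shown do not tell whether a sulfone, an amide or a tetrazole at the same place would hold the reading, or how a shorter chain carrying the methyl sulfoxide would fare. From the compounds shown here alone, since each reading comes from one concentration, the potency of compound 2 and compound 4 also remains open.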